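Notes on the chlorobenzyl change from compound 2 to compound 3

The compounds below may be only part of what the source reports. "The series", "measured", "known", "first", "only" and "open" are said of these compounds alone.

Measured in a functional assay on MDA-MB-231 cells (Homo sapiens) for cytotoxicity, read by MTT assay, with a stated time of 72 h (a lower number here means a stronger inhibitor, a higher number a weaker inhibitor), so far:
- compound 1 `CCN(CC)Cc1ccc2nc(NC(=O)N/N=C/c3cn(Cc4ccc(C(C)(C)C)cc4)c4ccccc34)sc2c1` gives 2120 nM
- compound 2 `CC1CCN(Cc2ccc3nc(NC(=O)N/N=C/c4cn(Cc5ccc(Cl)cc5Cl)c5ccccc45)sc3c2)CC1` gives 3140 nM

Only these two values are available. Among the measured compounds shown here, compound 2 stands at 3140 nM and so lies within the usual scatter of the only other measured compound, compound 1 at 2120 nM and no order between the two can be read.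

Compound 3 `CC1CCN(Cc2ccc3nc(NC(=O)N/N=C/c4cn(Cc5cccc(Cl)c5)c5ccccc45)sc3c2)CC1` keeps the rest of compound 2 and carries 3-chlorophenyl in place of 2,4-dichlorophenyl on a saturated chain carbon bound to an aromatic nitrogen. For the measured compounds named here, no measured pair shows this change on its own, so its effect has no direct precedent. Going by the values given here, the only guide is the narrow spread of the two values so far, compound 1 at 2120 nM and compound 2 at 3140 nM and that guide is thin.

The step expected in this assay is estimated as a 1.1-fold lower number from compound 2 to compound 3 (0.05 log units; within the scatter) and stays within the scatter, with no firm direction. For compound 3 the estimated value is 2800 nM with an expected range from 1100 nM to 7000 nM in this read-out.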

Compound 3, half-maximal inhibitory concentration: 2110 nM
Beside the measured number, compound 3's estimate is 1.3-fold (0.12 log units) above it; the measured number falls inside the stated range.
By their numbers in this assay, from the lowest: compounds 3, 1 and 2 (each within the scatter of the next).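

Among the compounds shown here, this is the first pair that differs in one place only: in this assay, 3-chlorobenzyl in place of 2,4-dichlorobenzyl gives a 1.5-fold lower number from compound 2 to compound 3 (0.17 log units; within the scatter), so the read-out does not separate the two groups. On a saturated chain carbon bound to an aromatic nitrogen, 3-chlorophenyl and 2,4-dichlorophenyl therefore cannot be told apart in this cytotoxicity read-out, at least with the 4-methylpiperidine side of compound 2 and compound 3 held fixed. No measurement at hand offers a reason for this result.

The pair alters the number of chlorines and their placement at once, so the two contributions cannot be read apart, and a single pair cannot show whether the result holds with another amine, such as the diethylamine of compound 1. As far as these compounds go, it also remains open whether a more different group at this place, such as an unsubstituted benzyl, a 4-methoxybenzyl or a benzyl bearing a carboxylic acid, would move the number beyond the scatter.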